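Amide in place of ether on the saturated ring carbon

The compounds below may be only part of what the source reports. "The series", "measured", "known", "first", "only" and "open" are said of these compounds alone.

Three members of the series carry the same shared core and differ only in the group on the oxygen on a saturated carbon. Compound 1 `Cc1nn(-c2ncnc3nc[nH]c23)c2c1C(OC1CCCC1)CC(=O)N2` bears cyclopentyl there and in a functional assay on HEK293 cells for agonist activity at G-protein coupled receptor 39 (Homo sapiens), read by scintillation proximity assay and inositol phosphate accumulation, with a stated time of 75 min (on this read-out higher numbers stand for an effect only at larger amounts of compound and lower numbers for an effect already at smaller amounts), compound 1 gives 62 nM. Compound 2 `Cc1nn(-c2ncnc3nc[nH]c23)c2c1C(OCCc1ccccc1)CC(=O)N2` bears phenethyl and in this assay compound 2 gives 40 nM. Compound 3 `Cc1nn(-c2ncnc3nc[nH]c23)c2c1C(OCc1ccccc1F)CC(=O)N2` bears 2-fluorobenzyl and in this assay compound 3 gives 78 nM. Compound 2 has the lowest number of the three, but its separation from the others is small: a 1.6-fold lower number from compound 1 to compound 2 (0.19 log units; within the scatter) and a 2.0-fold higher number from compound 2 to compound 3 (0.29 log units; within the scatter), so all three stand within the scatter of one another, as does a 1.3-fold higher number from compound 1 to compound 3 (0.10 log units; within the scatter).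

Compound 4 `Cc1nn(-c2ncnc3nc[nH]c23)c2c1C(C(=O)N(C)c1ccccc1)CC(=O)N2` departs from this set. Its difference from compound 2 is methyl(phenyl)carbamoyl in place of phenethyloxy on a saturated ring carbon. Among the compounds with values here, none of the measured steps bears directly on it: each of them swaps one group for another on the same oxygen, and each stayed within the scatter, whereas here the oxygen itself leaves and a methyl(phenyl)carbamoyl enters. The measured record shows that varying the group at this position has little effect, so the working expectation for compound 4 in this assay is a number near those of compounds 1 to 3, with wider uncertainty than the measured steps because the ether link is gone.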

Compound 4, half-maximal effective concentration: 5220 nM
Beside the measured number, compound 4's estimate is 58-fold (1.76 log units) below it; the measured number lies above the stated range.
By their numbers in this assay, from the lowest: compounds 2, 1 and 3 (each within the scatter of the next); then compound 4.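

In this assay, the saturated ring carbon proves far less forgiving than the ether series suggested: cyclopentyl, phenethyl and 2-fluorobenzyl on the oxygen stayed within the scatter of one another, yet replacing the whole ether with methyl(phenyl)carbamoyl gives a 130-fold higher number from compound 2 to compound 4 (2.12 log units; beyond the scatter), an 84-fold higher number from compound 1 to compound 4 (1.93 log units; beyond the scatter) and a 67-fold higher number from compound 3 to compound 4 (1.83 log units; beyond the scatter). All three steps are large and beyond the scatter whichever ether group leaves, so within these four compounds the loss goes with the change from ether to methyl(phenyl)carbamoyl and not with any one group on the oxygen, and the counts do not separate phenethyloxy from its replacement, since both have one six-membered aromatic ring of carbon only, no hydrogen-bond donors, one hydrogen-bond acceptor and no net charge. Nothing available here accounts for the size of this rise.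

With compound 4 as the only member lacking the ether, the compounds shown leave open which part of methyl(phenyl)carbamoyl goes with the higher number: the carbonyl, the methyl on the amide nitrogen or the phenyl ring. A phenylcarbamoyl group keeping the amide hydrogen, a benzylcarbamoyl group or a simple amine on the same ring carbon would begin to separate these parts.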